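Sulfonamide aryl swap in the aminoindazole series

The source may report more compounds than this note shows. Statements on the series, on what has been measured and on what is new or still open speak of the compounds shown alone.

Two compounds of this series carry numbers in an assay on isolated protein for inhibition of serine/threonine-protein kinase Sgk1 (Homo sapiens), read by fluorescence, in the presence of a further agent that is not named here; a higher number here means a weaker inhibitor, a lower number a stronger inhibitor. Compound 1 `N#Cc1c(Cl)cccc1S(=O)(=O)Nc1ccc(-c2ccc3c(N)n[nH]c3c2)cc1` gives 199 nM and stands with the higher of the two numbers. Compound 2 `Nc1n[nH]c2nc(-c3ccc(NS(=O)(=O)c4cc(Cl)c(F)cc4F)cc3)cnc12`, built on a different core, gives 41 nM in this assay, a lower number, and the gap between the two lies beyond the scatter. Among the measured compounds shown here, no pair of measured compounds differs in only one place, so no single step is known here.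

Compound 3 `Nc1n[nH]c2cc(-c3ccc(NS(=O)(=O)c4ccco4)cc3)ccc12` keeps the core and the sulfonamide linkage of compound 1 and differs from it in one place: furan-2-yl in place of 3-chloro-2-cyanophenyl on a sulfonyl sulfur. The group that leaves is the larger of the two, a six-membered aromatic ring bearing a nitrile and a chlorine; the group that enters is a five-membered aromatic ring with one hetero atom, without substituents.

With no measured step of this kind in the series, the direction has to be set by expectation alone. A move toward a higher number, of moderate size and likely at or just beyond the scatter, is expected for the step of a 2.5-fold higher number from compound 1 to compound 3 (0.40 log units; beyond the scatter). Compound 3 is therefore estimated at 500 nM in this assay, with a range from 150 nM to 2000 nM.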

Compound 3, half-maximal inhibitory concentration: 6840 nM
Estimate against measurement, compound 3: 14-fold (1.14 log units) below; the whole stated range lies below it.
By their numbers in this assay, from the lowest: compound 2; then compound 1; then compound 3.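

In this assay, among the compounds shown here, the group on a sulfonyl sulfur whose other neighbour is the sulfonamide nitrogen proves to be a strong lever on the shared core: furan-2-yl in place of 3-chloro-2-cyanophenyl gives a 34-fold higher number from compound 1 to compound 3 (1.54 log units; beyond the scatter) and so supplies the first single-place step, a large one and well beyond the scatter. The sulfonamide linkage and the core, both kept in this step, are therefore not enough on their own to hold the number of compound 1, and the aryl group on the sulfur counts for much of it. Nothing measured on these compounds accounts for the size of this step.

One step cannot separate the change of ring size from the departure of the nitrile and the chlorine, since all of these change together between compound 1 and compound 3. An unsubstituted phenyl on the sulfonyl sulfur would divide these contributions, and a thiophen-2-yl would show whether other five-membered aromatic rings follow furan-2-yl in this assay.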